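This account rests on a few compounds, and the source may have more. Where it says the series, first, only, none or still open, it means among the compounds named here.

Compound 2, `O=c1ccoc2cc(OCc3cn(Cc4cccc([N+](=O)[O-])c4)nn3)ccc12`, in a functional assay on SW480 cells (Homo sapiens) for cytotoxicity, read by MTT assay, with a stated time of 48 h (a higher number here means a weaker inhibitor, a lower number a stronger inhibitor), gives > 100000 nM, which is a limit of the assay rather than a measured number. Compound 1, `O=c1ccoc2cc(OCc3cn(Cc4ccc(Cl)cc4)nn3)ccc12`, likewise gives > 100000 nM, also a limit. Within the data shown here, the step that the two limits leave unreadable from compound 1 to compound 2 therefore cannot be sized, and the limit of > 100000 nM in this assay, at which 2 of the 2 values shown sit, is the only evidence available. Compound 3, `COc1ccc(Cn2cc(COc3ccc4c(=O)ccoc4c3)nn2)cc1`, differs from compound 2 by 4-methoxyphenyl in place of 3-nitrophenyl on a saturated chain carbon bound to an aromatic nitrogen. Among the measured compounds shown here, no measured step reads the effect of this change, so any expectation rests on the two limits alone. Compound 3 is expected to give about 100000 nM, between 30000 nM and 300000 nM. The expected step of a number no higher from compound 2 to compound 3 (the limit leaves the size open) is thus none beyond the scatter.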

Compound 3, half-maximal inhibitory concentration: 20400 nM
Beside the measured number, compound 3's estimate is 4.9-fold (0.69 log units) above it; the measured number lies below the stated range.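

In this assay, placing 4-methoxyphenyl on a saturated chain carbon bound to an aromatic nitrogen gives an at least 4.9-fold lower number from compound 2 to compound 3 (0.69 log units; beyond the scatter), and methoxy in place of chloro on an aromatic carbon gives an at least 4.9-fold lower number from compound 1 to compound 3 (0.69 log units; beyond the scatter). This shows what the two earlier compounds could not: the number at this position can change with the group it carries. The true size of each step stays open, since one end of each is a limit: the limit of > 100000 nM in this assay, at which 2 of the 3 values shown sit.

As far as these compounds go, it remains open whether an amine or a hydroxyl on the same ring would lower the number further. A longer chain in place of the methoxy methyl is equally untested by the compounds shown.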